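A few compounds are considered here, and "the series" means these few. Any claim that something is new, unique, unknown or untested is made for them only; others in the source may bear on it.

Measured compounds:
compound 1 `COc1ccccc1NC(=O)Oc1cc(=O)n(CCCO)c2c1CC(C/C=C(\C)CCC=C(C)C)C(C)(C)C2` — 0%
compound 2 `CC(C)=CCC/C(C)=C/CC1Cc2c(OC(=O)Nc3ccccc3F)cc(=O)n(CCCO)c2CC1(C)C` — 0%
compound 3 `CC(C)=CCC/C(C)=C/CC1Cc2c(OC(=O)Nc3ccc(F)c(Cl)c3)cc(=O)n(CCCO)c2CC1(C)C` — 0%

In a functional assay on PANC-1 cells (Homo sapiens) for inhibition, read by MTT assay, with a stated time of 24 h, tested at 10 uM (on this read-out higher numbers stand for more inhibition at the one concentration tested (going by the name of the read-out) and lower numbers for less inhibition), compound 1 gives 0%, compound 2 gives 0% and compound 3 gives 0%. The three compounds share one core and differ only in the aryl group on the carbamate nitrogen. None of the changes among them moved the read-out: no change at the digits printed from compound 1 to compound 2 (within the scatter), no change at the digits printed from compound 1 to compound 3 (within the scatter) and no change at the digits printed from compound 2 to compound 3 (within the scatter). Compound 3 therefore stands level with compound 1 and compound 2, with no ordering among the three possible.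

Compound 4 `CC(C)=CCC/C(C)=C/CC1Cc2c(OC(=O)Nc3cccc(C(F)(F)F)c3)cc(=O)n(CCCO)c2CC1(C)C` carries the next variation at the same place: 3-(trifluoromethyl)phenyl in place of 3-chloro-4-fluorophenyl on an amide-type nitrogen. All three measured steps, each a swap of one aryl group on the carbamate nitrogen for another, bear on this change, and each was flat within the scatter. Nothing in the data suggests that a further aryl swap would behave differently, so a step of no change at the digits printed from compound 3 to compound 4 (within the scatter) is expected, with no change beyond the scatter. For compound 4 in this assay the estimate is 0%, within a range of -5% to 12%.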

Compound 4, a percentage reported as inhibition, at one concentration (the size of the read-out at that concentration, not a potency): 6.7%
Beside the measured number, compound 4's estimate is 6.7 percentage points below it; low and high end bracket the measured number.
By their numbers in this assay, from the lowest: compounds 1, 2, 3 and 4 (each within the scatter of the next).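

In this assay, the swap to 3-(trifluoromethyl)phenyl on the amide-type nitrogen reads as a number 6.7 percentage points higher from compound 3 to compound 4 (within the scatter), and the same group read against the other two aryl groups gives a number 6.7 percentage points higher from compound 2 to compound 4 (within the scatter) and a number 6.7 percentage points higher from compound 1 to compound 4 (within the scatter). This extends the flat picture to a fourth aryl group, one with 10 heavy atoms against the 8 of 3-chloro-4-fluorophenyl, so the four groups at this position cannot be told apart at the one concentration tested. No measurement here offers an explanation for the number given by compound 4.

The compounds shown leave open whether a phenyl ring carrying an amine or a carboxylic acid would read differently from these four. They also leave open what a plain alkyl chain in place of the aryl group on the amide-type nitrogen would give.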